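A few compounds are considered here, and "the series" means these few. Any claim that something is new, unique, unknown or untested is made for them only; others in the source may bear on it.

Three compounds built on the core of compound 1 `CCC(=O)Nc1ncc(-c2ccc(OC)cc2)n1C` have so far been tested in a toxicity assay on THP-1 cells (Homo sapiens) for inhibition; on this read-out lower numbers stand for higher toxicity in this test and higher numbers for lower toxicity in this test. In this assay compound 1 gives > 100000 nM, which is a limit of the assay and not a number. Compound 2 `COc1ccc(-c2cnc(NC(=O)c3ccc(Cl)cc3)n2C)cc1` in this assay gives > 100000 nM, again a limit. Compound 3 `COc1ccc(-c2cnc(NC(=O)c3ccc(Br)cc3)n2C)cc1` in this assay gives > 100000 nM, also a limit. For the measured compounds named here, compound 3 therefore stands where every value so far sits, at the limit of > 100000 nM in this assay, at which 3 of the 3 values shown sit. The steps a step that the two limits leave unreadable from compound 1 to compound 3 and a step that the two limits leave unreadable from compound 2 to compound 3 both end in limits and give no readable size.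

Compound 4 `COc1ccc(-c2cnc(NC(=O)c3ccccc3C#N)n2C)cc1` differs from compound 3 by 2-cyanophenyl in place of 4-bromophenyl on a carbonyl carbon. Going by the values given here, no measured step carries a readable size for a change of this kind, and all three values rest on the same limit (the limit of > 100000 nM in this assay, at which 3 of the 3 values shown sit). A step no larger than the scatter is therefore expected, as a step that the limit leaves unreadable from compound 3 to compound 4. Compound 4 is estimated in this assay at 150000 nM, with a range from 50000 nM to 500000 nM, most likely reported again as a limit.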

Compound 4, half-maximal cytotoxic concentration: > 100000 nM
Compound 4 ended at the assay's limit; the forecaster's own chance of this, stated with the estimate: 80%; the middle value does not contradict the limit.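

Compound 4 ends at a limit in this assay, as do compound 1, compound 2 and compound 3, so none of the steps to compound 4 can be read: the limit of > 100000 nM in this assay, at which 4 of the 4 values shown sit.

The compounds shown leave open whether any change on the carbonyl carbon shifts the half-maximal cytotoxic concentration, and by how much.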